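The source may report more compounds than this note shows. Statements on the series, on what has been measured and on what is new or still open speak of the compounds shown alone.

Three compounds have been measured in a functional assay on K562 cells (Homo sapiens) for inhibition, read by MTT assay, with a stated time of 48 h; a lower number here means a stronger inhibitor, a higher number a weaker inhibitor:
compound 1 `CC(C)(C)C(=O)Nc1ccc(-c2cccc(C(=O)N[C@H]3CN[C@@H](C(=O)Nc4ccc(Cl)c(C(F)(F)F)c4)C3)c2)cn1` gives 28000 nM;
compound 2 `CC(=O)Nc1ccc(-c2cccc(C(=O)N[C@H]3CN[C@@H](C(=O)Nc4ccc(Cl)c(C(F)(F)F)c4)C3)c2)cn1` gives 8710 nM;
compound 3 `CC(=O)Nc1ccc(-c2cccc(C(=O)N[C@@H](C)C(=O)Nc3ccc(Cl)c(C(F)(F)F)c3)c2)cn1` gives 42800 nM.

Compound 1 and compound 2 share one core and differ in a single place: tert-butyl in place of methyl on a carbonyl carbon. This change gave a 3.2-fold higher number from compound 2 to compound 1 (0.51 log units; beyond the scatter). Compound 3 is built on a different core; the difference between the two cores is not broken down here. The numbers for compound 3 and compound 1 lie within the scatter of each other, while the number for compound 2 is clearly lower than both.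

Compound 4 `C[C@H](NC(=O)c1cccc(-c2ccc(NC(=O)C(C)(C)C)nc2)c1)C(=O)Nc1ccc(Cl)c(C(F)(F)F)c1` has not yet been measured. It differs from compound 3 in one place: tert-butyl in place of methyl on a carbonyl carbon. The place is the same as in the pair above, so this is the same change made on the other core. Because a 3.2-fold higher number from compound 2 to compound 1 (0.51 log units; beyond the scatter) went toward a weaker inhibitor, a step of similar direction and size is expected here, though the second core may not answer the same way, so the expectation is loose. The expected step is a 2.6-fold higher number from compound 3 to compound 4 (0.41 log units; beyond the scatter). Compound 4 is expected to give 110000 nM, with a range from 40000 nM to 280000 nM.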

Compound 4, half-maximal inhibitory concentration: 18400 nM
For compound 4 the middle estimate is 6.0-fold (0.78 log units) above the measured one, outside the stated range (below it).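

In this assay, putting tert-butyl in place of methyl on the carbonyl carbon gave a 2.3-fold lower number from compound 3 to compound 4 (0.37 log units; beyond the scatter), so on the core of compound 3 this change goes toward a stronger inhibitor. On the core of compound 1 the same change went toward a weaker inhibitor, so in this series the step did not carry over from one core to the other, in direction or in size: the same change on two cores in this assay, a 3.2-fold higher number (0.51 log units; beyond the scatter) from compound 2 to compound 1 and a 2.3-fold lower number (0.37 log units; beyond the scatter) from compound 3 to compound 4, 7.5-fold (0.87 log units) apart, beyond the scatter of two such steps This shows that the result of this change depends on the core that carries it in these two pairs, but it does not show why, and two pairs cannot predict how a further core would answer.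

The compounds shown hold only methyl and tert-butyl at this place, so it remains open how ethyl or isopropyl would behave on each core, and whether the two cores would part gradually as the group grows. A chain ending in an amine or a carboxylic acid at the same carbonyl carbon is also an open case.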